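Bromo-to-cyano step on the sulfonyl aryl ring

A few compounds are considered here, and "the series" means these few. Any claim that something is new, unique, unknown or untested is made for them only; others in the source may bear on it.

Measured compounds in a functional assay on QGY-7703 cells (Homo sapiens) for cytotoxicity, read by MTT assay, with a stated time of 24 h; a lower number here means a stronger inhibitor, a higher number a weaker inhibitor:
compound 1, `O=C1/C(=C/c2ccncc2)CN(S(=O)(=O)c2ccc(Br)cc2)C/C1=C\c1ccccc1F`, gives 11500 nM
compound 2, `N#Cc1ccc(S(=O)(=O)N2C/C(=C\c3ccncc3)C(=O)/C(=C/c3ccccc3F)C2)cc1`, gives 8500 nM
compound 3, `O=C1/C(=C/c2cccnc2)CN(S(=O)(=O)c2ccc(Br)cc2)C/C1=C\c1ccccc1C(F)(F)F`, gives 5510 nM

Compound 1 and compound 2 share one core; the change between them is cyano in place of bromo on an aromatic carbon. In this assay this gave a 1.4-fold lower number from compound 1 to compound 2 (0.13 log units; within the scatter). Compound 3 carries a different core, and the difference between the two cores is not broken down here. In this assay the gap between compound 3 and compound 2 lies within the scatter, while the gap between compound 3 and compound 1 lies beyond it.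

Compound 4, `N#Cc1ccc(S(=O)(=O)N2C/C(=C\c3cccnc3)C(=O)/C(=C/c3ccccc3C(F)(F)F)C2)cc1`, is not yet measured. It differs from compound 3 by cyano in place of bromo on an aromatic carbon, the same change as from compound 1 to compound 2, at the same place; among the compounds shown it occurs two times in all. The step is expected to be a 1.4-fold lower number from compound 3 to compound 4 (0.14 log units; within the scatter), about the size of a 1.4-fold lower number from compound 1 to compound 2 (0.13 log units; within the scatter), resting on that one earlier pair alone. Compound 4 is accordingly estimated at 4000 nM in this assay, with an expected range from 2000 nM to 9000 nM.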

Compound 4, half-maximal inhibitory concentration: 6150 nM
The estimate for compound 4 lay 1.5-fold (0.19 log units) below the measured number, and the stated range covers the measured number.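

In this assay the new step reads a 1.1-fold higher number from compound 3 to compound 4 (0.05 log units; within the scatter), and it can be set against the earlier one: the same change on two cores in this assay, a 1.4-fold lower number (0.13 log units; within the scatter) from compound 1 to compound 2 and a 1.1-fold higher number (0.05 log units; within the scatter) from compound 3 to compound 4, 1.5-fold (0.18 log units) apart, within the scatter of two such steps. Cyano in place of bromo on the sulfonyl aryl ring thus carries from the core of compound 1 to the core of compound 3 with no step difference that can be told apart, and on both cores the step stays within the scatter. This rests on two pairs alone, so it shows neither a gain nor a loss from the change on either core, and it does not show that the same would hold on a third core.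

Still open, from the compounds shown here alone, is whether another group in place of bromo on that aromatic carbon, such as an amine, a carboxylic acid or a longer chain, would move the number beyond the scatter. Going by these compounds, the difference between the two cores is also not broken down, so the share of each of its parts in the number remains unknown.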